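Cyclopropylsulfonyl Replaces an Aroyl Group on a Ring Nitrogen

The source may hold more compounds than are shown below. What is called first, only, known or untested is meant among the compounds shown, and "the series" means these compounds.

Compound 1, `CN1CCN(c2ccc(C3=NNC(c4ccc(N(C)C)cc4)C3)cc2)CC1`: 2.4%
Compound 2, `CN(C)c1ccc(C2CC(c3ccc(-n4cncn4)cc3)=NN2)cc1`: -3.3%
Compound 3, `Cc1ccc(C(=O)N2N=C(c3ccc(N4CCN(C)CC4)cc3)CC2c2ccc(N(C)C)cc2)cc1`: -0.4%

Of the compounds shown here, three sharing one core have been tested in a functional assay on NCI-H1975 cells (Homo sapiens) for inhibition, read by sulforhodamine B assay, tested at 10 uM (a higher number here means more inhibition at the concentration tested (going by the name of the read-out), a lower number less inhibition), and none of them reaches a number that separates it from the others. Compound 3 gives -0.4% in this assay and sits between its two neighbours: the nearest is compound 1, reached by a number 2.8 percentage points lower from compound 1 to compound 3 (within the scatter), and the furthest is compound 2, whose -3.3% likewise differs from compound 3 by less than the scatter. Among the compounds with values here, the one other step, a number 5.7 percentage points lower from compound 1 to compound 2 (within the scatter), is also within the scatter.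

Compound 4, `CN1CCN(c2ccc(C3=NN(S(=O)(=O)C4CC4)C(c4ccc(N(C)C)cc4)C3)cc2)CC1`, is not yet measured. It differs from compound 3 by cyclopropylsulfonyl in place of (4-methylphenyl)carbonyl on an amine nitrogen in a ring. The step that bears most directly on this change is the one at the same amine nitrogen, a number 2.8 percentage points lower from compound 1 to compound 3 (within the scatter), where a hydrogen gave way to the aroyl group with no effect beyond the scatter; the swap at the other end of the molecule, a number 5.7 percentage points lower from compound 1 to compound 2 (within the scatter), was equally flat. Compound 4 is therefore expected to show a step of a number 0.4 percentage points higher from compound 3 to compound 4 (within the scatter), that is nothing beyond the scatter. The estimate for compound 4 in this assay is 0%, within a range from -10% to 12%.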

Compound 4, a percentage reported as inhibition, at one concentration (the size of the read-out at that concentration, not a potency): 0.2%
For compound 4 the middle estimate is 0.2 percentage points below the measured one, within the range that was stated.
By their numbers in this assay, from the lowest: compounds 2, 3, 4 and 1 (each within the scatter of the next).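

In this assay, within the data shown here, the amine nitrogen in a ring now carries a sulfonyl-linked group for the first time, whereas the earlier compounds showed only hydrogen and (4-methylphenyl)carbonyl at this place: putting cyclopropylsulfonyl in place of (4-methylphenyl)carbonyl gives a number 0.6 percentage points higher from compound 3 to compound 4 (within the scatter), and putting it in place of hydrogen gives a number 2.2 percentage points lower from compound 1 to compound 4 (within the scatter). Compounds 1, 3 and 4 therefore form a set of three different substituents at this one nitrogen whose numbers cannot be told apart, so neither the carbonyl nor the sulfonyl link, nor the aromatic ring or three-membered ring carried on it, separates these compounds here. Nothing is available that would explain this flat result.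

From the compounds shown here alone, whether a basic amine, a carboxylic acid or a longer alkyl chain on this ring nitrogen would give a number beyond the scatter remains open. Also open, going by these compounds, is whether cyclopropylsulfonyl would read the same with 1H-1,2,4-triazol-1-yl at the far end of the molecule in place of 4-methylpiperazin-1-yl.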